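Cytotoxicity notes on a coumarin-ether series: phenyl for trifluoromethoxy

The source may report more compounds than this note shows. Statements on the series, on what has been measured and on what is new or still open speak of the compounds shown alone.

Measured so far:
compound 1 `Cc1c(Cc2ccccc2)c(=O)oc2cc(OCC(O)CNc3nccs3)ccc12` — 93000 nM
compound 2 `Cc1c(Cc2ccc(OC(F)(F)F)cc2)c(=O)oc2cc(OCC(O)CNc3nccs3)ccc12` — 99000 nM

In an ADME assay on A549 cells (Homo sapiens) for cytotoxicity, read by CellTiter-Glo (a higher number here means that more compound is tolerated, a lower number that less compound is tolerated), compound 2 gives 99000 nM, the highest of the two numbers, with compound 1 nearest at a 1.1-fold higher number from compound 1 to compound 2 (0.03 log units; within the scatter). Compound 3 `Cc1c(Cc2ccc(-c3ccccc3)cc2)c(=O)oc2cc(OCC(O)CNc3nccs3)ccc12` differs from compound 2 by phenyl in place of trifluoromethoxy on an aromatic carbon. For the measured compounds named here, the only measured step, from compound 1 to compound 2, exchanged a hydrogen for trifluoromethoxy at this position and stayed within the scatter; no measured step covers a phenyl entering there. On that basis no change beyond the scatter is expected for compound 3, estimated at 80000 nM (range 40000 nM to 160000 nM), a step of a 1.2-fold lower number from compound 2 to compound 3 (0.09 log units; within the scatter).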

Compound 3, half-maximal cytotoxic concentration: 38100 nM
Compound 3: the middle estimate sits 2.1-fold (0.32 log units) above what was measured; the whole stated range lies above it.
By their numbers in this assay, from the lowest: compound 3; then compounds 1 and 2 (each within the scatter of the next).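

In this assay this position, para to a large group, is not indifferent to what it carries: phenyl gives a 2.6-fold lower number from compound 2 to compound 3 (0.41 log units; beyond the scatter) and a 2.4-fold lower number from compound 1 to compound 3 (0.39 log units; beyond the scatter) as well, both modest. Tolerance of trifluoromethoxy here therefore does not extend to every group, and of the three compounds only compound 3 stands apart. Nothing available accounts for this step. On these data alone, whether an amine, a carboxylic acid or a longer alkyl chain at this carbon would track phenyl or trifluoromethoxy stays open, as does the effect of a saturated ring such as cyclohexyl.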